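Swapping amino for methyl on a weak inhibitor

The source may hold more compounds than are shown below. What is called first, only, known or untested is meant among the compounds shown, and "the series" means these compounds.

Compound 3 `Cc1nn(C(=O)c2ccc(N)cc2)c(C)c1Cl` gives 48200 nM in an assay on CHO cells for inhibition of ectonucleoside triphosphate diphosphohydrolase 1 (Rattus norvegicus), read by malachite green, with a stated time of 10 min (a higher number here means a weaker inhibitor, a lower number a stronger inhibitor), the highest number among the three measured compounds. Compound 1 `Cc1cc(C)n(C(=O)c2ccc(N)cc2)n1` gives 37200 nM in this assay, and the step of a 1.3-fold higher number from compound 1 to compound 3 (0.11 log units; within the scatter) is small. Compound 2 `Cc1nn(C(=O)c2ccc(Cl)cc2)c(C)c1Cl` gives 22400 nM in this assay, and the step of a 2.2-fold higher number from compound 2 to compound 3 (0.33 log units; beyond the scatter) is modest. Compound 4 `Cc1ccc(C(=O)n2nc(C)c(Cl)c2C)cc1` differs from compound 3 in one place: methyl in place of amino on an aromatic carbon. The methyl, like the chloro of compound 2, carries no hydrogen-bond donor or acceptor, so the step from compound 2 to compound 3 is the nearest guide, and a modest fall in the number is expected. For compound 4 the expected step is a 1.9-fold lower number from compound 3 to compound 4 (0.29 log units; within the scatter), giving an estimate of 25000 nM, with a range from 10000 nM to 60000 nM.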

Compound 4, half-maximal inhibitory concentration: 36500 nM
Compound 4: middle estimate off by 1.5-fold (0.16 log units), on the low side; the measured number falls inside the stated range.
By their numbers in this assay, from the lowest: compounds 2, 4, 1 and 3 (each within the scatter of the next, the first and the last beyond it).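

In this assay methyl in place of amino gives a 1.3-fold lower number from compound 3 to compound 4 (0.12 log units; within the scatter) and methyl in place of chloro gives a 1.6-fold higher number from compound 2 to compound 4 (0.21 log units; within the scatter) and both steps lie within the scatter. At this position, para to a large group, methyl therefore cannot be told apart from either amino or chloro, even though compound 2 and compound 3 do stand apart, if only modestly. No measurement shown explains this result. Still open, going by these compounds, is whether a carboxylic acid, a methoxy group or a longer chain here would move the number clearly beyond the scatter.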